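The compounds below may be only part of what the source reports. "The series", "measured", "known", "first", "only" and "open" are said of these compounds alone.

The compounds measured so far, all read in an assay on microsomes from intestine for inhibition of acyl-CoA:cholesterol acyltransferase (Oryctolagus cuniculus); on this read-out higher numbers stand for weaker inhibition and lower numbers for stronger inhibition:

Compound 1, `Cc1cc(C)c(NC(=O)N(Cc2ccc(-c3ccccn3)cc2)C2CCCCCC2)c(C)c1`, gives 33 nM.
Compound 2, `Cc1cc(C)c(NC(=O)N(Cc2ccc(-n3cccn3)cc2)C2CCCCCC2)c(C)c1`, gives 70 nM.
Compound 3, `Cc1cc(C)c(NC(=O)N(Cc2ccc(-c3cc[nH]n3)cc2)C2CCCCCC2)c(C)c1`, gives 52 nM.

Compound 3 stands in the middle of these three numbers: the gap from compound 2 to compound 3 is a 1.3-fold lower number from compound 2 to compound 3 (0.13 log units; within the scatter), and the gap from compound 1 to compound 3 is a 1.6-fold higher number from compound 1 to compound 3 (0.20 log units; within the scatter), so neither separates it from its neighbours. Compound 4, `Cc1cc(C)c(NC(=O)N(Cc2ccc(-n3ccnc3)cc2)C2CCCCCC2)c(C)c1`, is the next member of the series and carries the change (1H-imidazol-1-yl in place of 1H-pyrazol-3-yl on an aromatic carbon). Among the measured compounds shown here, two measured steps bear on it. The step from compound 1 to compound 2, a 2.1-fold higher number from compound 1 to compound 2 (0.33 log units; beyond the scatter), is the only one in the set that goes beyond the scatter and also the only one that introduces a nitrogen-linked azole; the step from compound 2 to compound 3, a 1.3-fold lower number from compound 2 to compound 3 (0.13 log units; within the scatter), shows that the nitrogen-linked and carbon-linked pyrazoles sit close together. On this basis the expected change in this assay from compound 3 to compound 4 is a 1.3-fold higher number from compound 3 to compound 4 (0.13 log units; within the scatter), not beyond the scatter. Compound 4 is therefore estimated at 70 nM, within a range from 30 nM to 160 nM.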

Compound 4, half-maximal inhibitory concentration: 47 nM
Compound 4: middle estimate off by 1.5-fold (0.17 log units), on the high side; the range from low to high includes it.
By their numbers in this assay, from the lowest: compounds 1, 4, 3 and 2 (each within the scatter of the next, the first and the last beyond it).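

At this position, para to a large group, 1H-imidazol-1-yl in place of 1H-pyrazol-3-yl takes the ring from 1 hydrogen-bond donor, 1 hydrogen-bond acceptor to 0 hydrogen-bond donors, 2 hydrogen-bond acceptors, yet this assay reads no change beyond the scatter (a 1.1-fold lower number from compound 3 to compound 4 (0.04 log units; within the scatter)). The two nitrogen-linked azoles also stay within the scatter of each other (a 1.5-fold lower number from compound 2 to compound 4 (0.17 log units; within the scatter)). Compound 4 further stays within the scatter of the pyridin-2-yl compound (a 1.4-fold higher number from compound 1 to compound 4 (0.15 log units; within the scatter)), so a nitrogen-linked azole does not as such separate a compound from compound 1, and only compound 2 does so.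

Going by these compounds, whether an amine, a carboxylic acid or a longer chain at this position would hold the number in the same range remains open. No evidence is at hand on what lies behind these small differences.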